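Ethynyl for thiophen-3-yl in the series

The source may hold more compounds than are shown below. What is called first, only, known or untested is meant among the compounds shown, and "the series" means these compounds.

Values so far in a functional assay on A549 cells (Homo sapiens), read by MTT assay, with a stated time of 72 h; a lower number here means a stronger inhibitor, a higher number a weaker inhibitor
- compound 1 `C#Cc1cn([C@@H]2O[C@H](CO)[C@@H](O)[C@H]2O)c2ncnc(OC)c12` gives 8160 nM
- compound 2 `C#Cc1cn([C@@H]2O[C@H](CO)[C@@H](O)[C@H]2O)c2ncnc(N(C)C)c12` gives 390 nM
- compound 3 `Cc1ncnc2c1c(-c1ccsc1)cn2[C@@H]1O[C@H](CO)[C@@H](O)[C@H]1O` gives > 20000 nM (a limit of the assay, not a number)

Compound 3 stands at the limit of > 20000 nM in this assay, at which 1 of the 3 values shown sits, and so offers no number to start from. Compound 4 `C#Cc1cn([C@@H]2O[C@H](CO)[C@@H](O)[C@H]2O)c2ncnc(C)c12` differs from it by ethynyl in place of thiophen-3-yl on an aromatic carbon (ethynyl in place of thiophen-3-yl on an aromatic carbon of the five-membered aromatic ring). Going by the values given here, no measured step makes this exchange. The nearest evidence is that the two compounds carrying ethynyl both give numbers, compound 1 at 8160 nM and compound 2 at 390 nM. Between them lies a 21-fold lower number from compound 1 to compound 2 (1.32 log units; beyond the scatter) (a large step), made at the other substituted position, where compound 4 differs from both, so a wide range is needed. In this assay a large move towards a lower number is expected, estimated as an at least 10-fold lower number from compound 3 to compound 4 (1.00 log units; beyond the scatter) (true size open). Compound 4 is estimated at 2000 nM (expected range 300 nM to 12000 nM).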

Compound 4, half-maximal inhibitory concentration: 19200 nM
Beside the measured number, compound 4's estimate is 9.6-fold (0.98 log units) below it; measured number outside the range, above it.
By their numbers in this assay, from the lowest: compound 2; then compound 1; then compound 4. At a limit, above all of these: compound 3.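

In this assay, ethynyl in place of thiophen-3-yl gives an at least 1.0-fold lower number from compound 3 to compound 4 (0.01 log units; that floor lies within the scatter), so with methyl on the core this exchange shows no gain that can be separated from the scatter. Compound 3 stands at a limit of the assay, not a number: the limit of > 20000 nM in this assay, at which 1 of the 4 values shown sits.

With ethynyl held fixed, the other substituted position sets the value: methyl gives a 49-fold higher number from compound 2 to compound 4 (1.69 log units; beyond the scatter) and a 2.4-fold higher number from compound 1 to compound 4 (0.37 log units; beyond the scatter), placing dimethylamino clearly ahead of both methoxy and methyl.

Still open, going by these compounds, is how thiophen-3-yl reads with dimethylamino at that other position, where a number might replace the limit. Also open, on these data alone, is whether the gain belongs to dimethylamino alone or extends to a primary amine or a longer dialkylamino chain.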